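From 4-methylpiperazin-1-yl to 1,3-thiazol-2-yl on one aromatic carbon

The compounds below may be only part of what the source reports. "The series", "measured", "known", "first", "only" and "open" are said of these compounds alone.

Three related compounds have a number in a physicochemical assay for solubility; on this read-out higher numbers stand for higher solubility and lower numbers for lower solubility. Compound 1 `CN1CCN(c2cc(C(F)(F)F)ccc2[C@H]2CCOc3cc(S(=O)(=O)Nc4nccs4)ccc32)CC1` gives 176000 nM, compound 2 `Cc1nc(-c2cc(C(F)(F)F)ccc2[C@H]2CCOc3cc(S(=O)(=O)Nc4ncc(F)cn4)ccc32)co1` gives 281000 nM, and compound 3 `Cn1nccc1-c1cc(C(F)(F)F)ccc1[C@H]1CCc2cc(S(=O)(=O)Nc3ncccn3)ccc21` gives 316000 nM. These numbers all lie within the usual scatter of repeated measurements, so compound 1 cannot be told apart from the other two.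

Compound 4 `O=S(=O)(Nc1nccs1)c1ccc2c(c1)OCC[C@@H]2c1ccc(C(F)(F)F)cc1-c1nccs1` has not yet been measured. It keeps the core of compound 1 and differs in one place, with 1,3-thiazol-2-yl in place of 4-methylpiperazin-1-yl on an aromatic carbon. That carbon sits on a six-membered aromatic ring of carbon only, ortho to a large group and meta to a trifluoromethyl group.

Within the data shown here, no two measured compounds differ in only one place, so this swap has no direct precedent in the data. Among the measured compounds shown here, the only indirect guide is that compound 2, at 281000 nM, and compound 3, at 316000 nM, also lack the 4-methylpiperazin-1-yl group and still sit within the scatter of compound 1, at 176000 nM. No change beyond the scatter is therefore expected in this assay, in either direction. The expected step is a 1.1-fold higher number from compound 1 to compound 4 (0.06 log units; within the scatter). For compound 4 the estimated value is 200000 nM, with an expected range from 70000 nM to 450000 nM.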

Compound 4, solubility: 15000 nM
Compound 4: middle estimate off by 13-fold (1.12 log units), on the high side; measured number below the stated range.
By their numbers in this assay, from the lowest: compound 4; then compounds 1, 2 and 3 (each within the scatter of the next).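

In this assay, the aromatic carbon ortho to a large group and meta to a trifluoromethyl group proves sensitive to what it carries: 1,3-thiazol-2-yl in place of 4-methylpiperazin-1-yl gives a 12-fold lower number from compound 1 to compound 4 (1.07 log units; beyond the scatter), a large step beyond the scatter. Among these compounds, the earlier compounds could not show this, as no two of them differed in only one place, so this is the first change at this carbon that can be read on its own, with the rest of compound 1 kept. Nothing measured here accounts for the size of the step, which therefore stands as an observation without an explanation.

On these data alone, what remains open is whether the step follows from losing 4-methylpiperazin-1-yl or from gaining 1,3-thiazol-2-yl, as this single pair cannot separate the two. Other groups on the same carbon of compound 1, such as a morpholine ring, a dimethylamino group or a carboxylic acid, would show whether the number tracks the kind of group placed there, and whether this one swap reflects a wider pattern at this position.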